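This account rests on a few compounds, and the source may have more. Where it says the series, first, only, none or still open, it means among the compounds named here.

Compound 1 `O=C(O)c1ccccc1-c1ccc(CCc2ncc(CCC3CCCCC3)[nH]2)cc1`: 642 nM
Compound 2 `Cc1ccc(Cc2cnc(CCc3ccc(-c4ccccc4C(=O)O)cc3)[nH]2)cc1`: 2660 nM

In an in vitro functional assay on cells for agonist activity at Bombesin receptor subtype-3 (Homo sapiens), read by luminescence and calcium flux (a higher number here means that more compound is needed for the effect, a lower number that less compound is needed), compound 2 gives the highest of the two numbers; its nearest neighbour is compound 1, reached by a 4.1-fold higher number from compound 1 to compound 2 (0.62 log units; beyond the scatter). Compound 3 `O=C(O)c1ccccc1-c1ccc(CCc2ncc(C3CCCCC3)[nH]2)cc1` differs from compound 2 by one change: cyclohexyl in place of 4-methylbenzyl on an aromatic carbon. Going by the values given here, the only measured step that bears on this, a 4.1-fold higher number from compound 1 to compound 2 (0.62 log units; beyond the scatter), went the other way, from a saturated ring on a chain to an aromatic one, and was modest. Returning to a saturated ring, now without the intervening chain carbon, is therefore expected to lower the number, roughly by a 3.3-fold lower number from compound 2 to compound 3 (0.52 log units; beyond the scatter). Compound 3 is estimated at 800 nM, within 300 nM to 2500 nM.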

Compound 3, half-maximal effective concentration: 375 nM
Estimate against measurement, compound 3: 2.1-fold (0.33 log units) above; low and high end bracket the measured number.
By their numbers in this assay, from the lowest: compounds 3 and 1 (each within the scatter of the next); then compound 2.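

In this assay, cyclohexyl in place of 4-methylbenzyl on this aromatic carbon gives a 7.1-fold lower number from compound 2 to compound 3 (0.85 log units; beyond the scatter), so the position responds clearly to this exchange. Cyclohexyl in place of 2-cyclohexylethyl gives a 1.7-fold lower number from compound 1 to compound 3 (0.23 log units; within the scatter), so the cyclohexyl ring keeps its number with or without the chain. No measurement here gives a reason for either step. The step from compound 2 changes the ring and its link together, so their shares remain unseparated. Going by these compounds, whether phenyl attached directly, or an open chain such as hexyl, would match cyclohexyl remains open.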